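A few compounds are considered here, and "the series" means these few. Any claim that something is new, unique, unknown or untested is made for them only; others in the source may bear on it.

In a functional assay on SW620/5-FU cells (Homo sapiens) for cytotoxicity, read by MTT assay, with a stated time of 48 h, in the presence of a further agent that is not named here (a higher number here means that more compound is needed for the effect, a lower number that less compound is needed), compound 1 `CCCc1cc(NNC(=O)Nc2cc(Cl)nc(Cl)c2)nc2c1c(C)nn2C`, which also carries propyl, gives 40800 nM and compound 2 `Cn1ncc2c(-c3ccccc3)cc(NNC(=O)Nc3cc(Cl)nc(Cl)c3)nc21` gives 76900 nM. These two values lie within the scatter of each other, so compound 2 stands apart from compound 1 by no real margin. Compound 3 `CCCc1cc(NNC(=O)Nc2cc(Cl)nc(Cl)c2)nc2c1cnn2C` differs from compound 2 by one change: propyl in place of phenyl on an aromatic carbon. For the measured compounds named here, no measured pair isolates this change, and no step beyond the scatter is expected in this assay. The estimated step is a 1.5-fold lower number from compound 2 to compound 3 (0.19 log units; within the scatter). For compound 3 the estimated value is 50000 nM, with an expected range of 22000 nM to 110000 nM.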

Compound 3, half-maximal effective concentration: 38700 nM
For compound 3 the middle estimate is 1.3-fold (0.11 log units) above the measured one; low and high end bracket the measured number.
By their numbers in this assay, from the lowest: compounds 3, 1 and 2 (each within the scatter of the next).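

In this assay, swapping phenyl for propyl on the aromatic carbon now forms a measured pair (a 2.0-fold lower number from compound 2 to compound 3 (0.30 log units; within the scatter)), and hydrogen in place of methyl on an aromatic carbon forms a second (a 1.1-fold lower number from compound 1 to compound 3 (0.02 log units; within the scatter)). Both steps lie within the scatter, so neither change separates its two compounds in this assay. No measurement available here offers an explanation for this.

Still open, going by these compounds, is whether an amine, a carboxylic acid or a longer chain such as hexyl in the propyl position would give a step beyond the scatter. The compounds shown also leave untested any change outside these two positions.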